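Ether-to-ester linker change in a platelet-activating factor series

This account rests on a few compounds, and the source may have more. Where it says the series, first, only, none or still open, it means among the compounds named here.

Three compounds have numbers in a functional assay (Oryctolagus cuniculus) for inhibition of platelet-activating factor receptor (Cavia porcellus); on this read-out higher numbers stand for weaker inhibition and lower numbers for stronger inhibition. Compound 1 `CCCCCCCCCCCCCCCCOCC1COC(COC(=O)N(Cc2ccccn2)C(C)=O)C1` gives 11000 nM. Compound 2 `CCCCCCCCCCCCCCCCCCOCC1CC(COCCCCCCC[n+]2ccsc2)CO1` gives 3900 nM, the second highest of the three numbers; compound 1 sits higher by a gap beyond the usual scatter, while compound 3 `CCCCCCCCCCCCOCC1COC(COCCCCCCC[n+]2ccsc2)C1`, which gives 1100 nM, sits lower by a gap that is also beyond the scatter. Going by the values given here, no pair of these measured compounds differs in a single place, so no step between them is available.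

Compound 4 `CCCCCCCCCCCCCCCCCCOCC1CC(COC(=O)CCCCC[n+]2ccsc2)CO1` is not yet measured. Relative to compound 2 the change is a group of 12 heavy atoms (9 carbon, 1 nitrogen, 1 oxygen, 1 sulfur; one five-membered aromatic ring with 2 hetero atoms) in place of a group of 12 heavy atoms (10 carbon, 1 nitrogen, 1 sulfur; one five-membered aromatic ring with 2 hetero atoms), on an oxygen on a saturated carbon. Among the compounds with values here, with no measured step of this kind, only a small step, within the scatter, is expected in this assay, in either direction. The estimate for compound 4 in this assay is 5000 nM, expected to lie between 1500 nM and 15000 nM. The expected step is a 1.3-fold higher number from compound 2 to compound 4 (0.11 log units; within the scatter).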

Compound 4, half-maximal inhibitory concentration: 1500 nM
Compound 4: the middle estimate sits 3.3-fold (0.52 log units) above what was measured; low and high end bracket the measured number.
By their numbers in this assay, from the lowest: compounds 3 and 4 (each within the scatter of the next); then compound 2; then compound 1.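

In this assay, this position, on an oxygen on a saturated carbon, now has a first reading, with a 2.6-fold lower number from compound 2 to compound 4 (0.41 log units; beyond the scatter), so this swap is not neutral here. The two groups match in heavy-atom count and net charge +1, while the entering group carries 1 double bond outside aromatic rings and 2 hydrogen-bond acceptors against 1. No measured evidence bears on the reason for this step. Whether the carbonyl alone accounts for the step remains open, as does the outcome with an amide in the same place.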